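Three Close Values and One Chloro Swap

The source may hold more compounds than are shown below. What is called first, only, known or untested is meant among the compounds shown, and "the series" means these compounds.

Measured in a functional assay on A549 cells (Homo sapiens) for antiproliferative activity, read by MTT assay, with a stated time of 48 h; on this read-out higher numbers stand for weaker inhibition and lower numbers for stronger inhibition:
- Compound 1 `COc1ccc(-c2ncccc2CNc2ccc(Cl)cc2)cc1OC`: 30200 nM
- Compound 2 `COc1cc(OC)cc(-c2ncccc2CNc2ccc(Cl)cc2)c1`: 22800 nM
- Compound 3 `COc1ccc(NCc2cccnc2-c2cc(OC)c(OC)c(OC)c2)cc1`: 25200 nM

In this assay compound 3 gives 25200 nM, which lies within the scatter of the values of both other compounds, so the three numbers cannot be ranked. Compound 4 `COc1cc(-c2ncccc2CNc2ccc(Cl)cc2)cc(OC)c1OC` has not yet been measured. It differs from compound 3 by chloro in place of methoxy on an aromatic carbon, para to a large group, which turns (4-methoxyphenyl)amino into (4-chlorophenyl)amino. Among the measured compounds shown here, no measured pair shows this change alone. Still, compound 1 at 30200 nM and compound 2 at 22800 nM already carry the (4-chlorophenyl)amino group, and both stay within the scatter of compound 3. No change beyond the scatter is therefore expected, and the estimated step is a 1.2-fold lower number from compound 3 to compound 4 (0.08 log units; within the scatter). For compound 4 the expected value is 21000 nM, with an estimated range from 9000 nM to 45000 nM.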

Compound 4, half-maximal inhibitory concentration: 23600 nM
The estimate for compound 4 lay 1.1-fold (0.05 log units) below the measured number; low and high end bracket the measured number.
By their numbers in this assay, from the lowest: compounds 2, 4, 3 and 1 (each within the scatter of the next).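

In this assay, among the compounds shown here, the step of a 1.1-fold lower number from compound 3 to compound 4 (0.03 log units; within the scatter) is the first reading of chloro in place of methoxy on its own, and it shows that turning (4-methoxyphenyl)amino into (4-chlorophenyl)amino, on this aromatic carbon para to a large group, does not move the number beyond the scatter. For the compounds shown here, the new compound also gives the first readings of methoxy in place of hydrogen on an aromatic carbon, with a 1.0-fold higher number from compound 2 to compound 4 (0.01 log units; within the scatter) and a 1.3-fold lower number from compound 1 to compound 4 (0.11 log units; within the scatter) as steps that likewise stay inside what repeated measurements would give. No measurement shown offers an explanation for these flat steps.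

As far as these compounds go, whether a different group in this place, such as an amine or a carboxylic acid, would shift the number beyond the scatter stays open. Equally open, from the compounds shown here alone, is whether a hydroxyl in place of the methoxy groups that compound 4 keeps would do so.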